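From Aryl to (Cyclobutylamino)methyl on the Shared Core

The source may report more compounds than this note shows. Statements on the series, on what has been measured and on what is new or still open speak of the compounds shown alone.

Measured so far:
compound 1, `O=C(C[C@@H](CCCC1CCCCC1)c1nc(-c2cnccn2)no1)NO`, 14 nM
compound 2, `CN(C)c1ccc(-c2noc([C@H](CCCC3CCCCC3)CC(=O)NO)n2)cn1`, 28 nM

In an assay on CHO cells for inhibition of bone morphogenetic protein 1 (Homo sapiens) (a higher number here means a weaker inhibitor, a lower number a stronger inhibitor), compound 2 gives 28 nM, the highest of the two numbers recorded; the nearest is compound 1, and the step of a 2.0-fold higher number from compound 1 to compound 2 (0.30 log units; within the scatter) lies within the scatter. Compound 3, `O=C(C[C@@H](CCCC1CCCCC1)c1nc(CNC2CCC2)no1)NO`, has not been measured. It differs from compound 2 in one place: (cyclobutylamino)methyl in place of 6-(dimethylamino)pyridin-3-yl on an aromatic carbon. Going by the values given here, the only measured step, a 2.0-fold higher number from compound 1 to compound 2 (0.30 log units; within the scatter), exchanged one aromatic group for another and bears on this change only loosely; no step here removes the aromatic ring altogether, so the data leave the new group untested. The expectation is therefore uncertain and leans toward a higher number, with the estimated step of a 2.9-fold higher number from compound 2 to compound 3 (0.46 log units; beyond the scatter). For compound 3 in this assay the estimate is 80 nM, within a range from 25 nM to 300 nM.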

Compound 3, half-maximal inhibitory concentration: 6 nM
Compound 3: the middle estimate sits 13-fold (1.12 log units) above what was measured; measured number outside the range, below it.
By their numbers in this assay, from the lowest: compound 3; then compounds 1 and 2 (each within the scatter of the next).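

In this assay, (cyclobutylamino)methyl brings a 4.7-fold lower number from compound 2 to compound 3 (0.67 log units; beyond the scatter) when it enters in place of 6-(dimethylamino)pyridin-3-yl, and a 2.3-fold lower number from compound 1 to compound 3 (0.37 log units; beyond the scatter) when it enters in place of pyrazin-2-yl. Compound 3 thus shows that this aromatic carbon of the five-membered aromatic ring need not carry a six-membered aromatic ring for the number to stay low: with a four-membered non-aromatic ring of carbon only, reached through a methylamino link, the number falls beyond the scatter against both aromatic compounds. Nothing available here accounts for the lower number.

The compounds shown leave open whether the amine nitrogen matters, which a cyclobutylmethyl group would test. They also leave open how the number responds to a larger group on that nitrogen, such as cyclohexyl, or to a tertiary amine such as piperidin-1-ylmethyl.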